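The source may report more compounds than this note shows. Statements on the series, on what has been measured and on what is new or still open speak of the compounds shown alone.

Within the data shown here, compound 1 `CCCCCCCCCCCCCCCC(=O)OC[C@H](CSC[C@H](N)C(=O)NCC(=O)OC(C)C)OC(=O)CCCCCCCCCCCCCCC` is the only member of this short series with a numerical read-out: in a functional assay on HEK293 cells for agonist activity at Toll-like receptor 2 (Homo sapiens), read by spectrophotometry, with a stated time of 12 h (on this read-out higher numbers stand for an effect only at larger amounts of compound and lower numbers for an effect already at smaller amounts), compound 1 gives 0.45 nM. Compound 2 `CCCCCCCCCCCCCCCC(=O)OC[C@H](CSC[C@H](NC(=O)CC[C@H](N)C(=O)O)C(=O)NCC(=O)OC(C)C)OC(=O)CCCCCCCCCCCCCCC` returns only a limit of the assay, compound 2 giving > 1000 nM. Compound 3 `CCCCCCCCCCCCCCCCOC(=O)CCSC[C@H](N)C(=O)N[C@@H](CO)C(=O)OC` likewise returns a limit, compound 3 giving > 1000 nM. Substitution on the amine nitrogen, an at least 2200-fold higher number from compound 1 to compound 2 (3.34 log units; beyond the scatter), lands at the limit of > 1000 nM in this assay, at which 2 of the 3 values shown sit. Compound 4 `CCCCCCCCCCCCCCCC(=O)OC[C@H](CSCCC(=O)N[C@@H](CO)C(=O)OC)OC(=O)CCCCCCCCCCCCCCC` carries ((2-hydroxy-1-(methoxycarbonyl)ethyl)carbamoyl)methyl in place of amino(((isopropoxycarbonyl)methyl)carbamoyl)methyl on a saturated chain carbon bound to a sulfur, so the free amine of compound 1 is gone from the core of compound 1. Among the measured compounds shown here, no measured step covers exactly this change; the nearest one, the large loss on substituting the amine, points towards a large rise in this assay. Compound 4 is therefore expected near 300 nM, within 10 nM to 3000 nM. That corresponds to an expected step of a 670-fold higher number from compound 1 to compound 4 (2.82 log units; beyond the scatter), which may well again end at the assay limit.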

Compound 4, half-maximal effective concentration: > 1000 nM
Compound 4: only a limit was reported; the forecaster's own chance of this, stated with the estimate: 50%; middle value at least 3.3-fold (0.52 log units) from the limit.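

In this assay compound 4 gives > 1000 nM, which is a limit of the assay and not a number. Where the earlier step substituted the amine and kept it in place, this change on a saturated chain carbon bound to a sulfur removes the whole amino(((isopropoxycarbonyl)methyl)carbamoyl)methyl group, with an at least 2200-fold higher number from compound 1 to compound 4 (3.34 log units; beyond the scatter). The two changes therefore cannot be ranked, as each ends at the same limit: the limit of > 1000 nM in this assay, at which 3 of the 4 values shown sit.

Whether the missing amine alone accounts for the loss stays open, as the entering group also carries a hydroxyl and a methyl ester. The ((2-hydroxy-1-(methoxycarbonyl)ethyl)carbamoyl)methyl group with an added amine would separate these contributions.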